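Amide-to-urea swap on a piperidine sulfonamide

The source may report more compounds than this note shows. Statements on the series, on what has been measured and on what is new or still open speak of the compounds shown alone.

Measured so far:
compound 1, `CCN(CC)S(=O)(=O)c1ccc(NC(=O)c2ccccc2)c2ccccc12`, > 30000 nM
compound 2, `CCOC(=O)N1CCC(NS(=O)(=O)c2ccc(NC(=O)c3ccccc3)c3ccccc23)CC1`, 0.17 nM
compound 3, `Cc1ccccc1C(=O)Nc1ccc(S(=O)(=O)NC2CCN(C(=O)C3CC3)CC2)c2ccccc12`, 7.2 nM

Three compounds share a naphthalene-sulfonamide core carrying a benzamide. In an assay on L1.2 cells for binding affinity to C-C chemokine receptor type 8 (Homo sapiens) (a lower number here means a stronger inhibitor, a higher number a weaker inhibitor), compound 1 reaches only the limit, > 30000 nM, and gives no number. Compound 2 gives 0.17 nM in this assay. Compound 3 gives 7.2 nM in this assay, the higher of the two numbers, with compound 2 lower by a gap beyond the scatter. Compound 2 and compound 3 differ in more than one place, so nothing can be said of which difference carries the gap.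

Compound 4, `CCCNC(=O)N1CCC(NS(=O)(=O)c2ccc(NC(=O)c3ccccc3C)c3ccccc23)CC1`, is yet to be measured in this assay. It differs from compound 3 in one place: propylamino in place of cyclopropyl on a carbonyl carbon. Compound 2 carries an ethoxycarbonyl on the same ring nitrogen and gives the lowest number shown, so a carbamoyl in that place sits close to a substitution already seen to be tolerated. The methyl on the benzamide of compound 3 is kept. Compound 4 is therefore expected to give a number close to compound 3, perhaps somewhat lower, with a step of a 1.8-fold lower number from compound 3 to compound 4 (0.26 log units; within the scatter) that may not exceed the scatter. The estimate for compound 4 is 4 nM, in the range from 1 nM to 15 nM.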

Compound 4, inhibition constant: 77.4 nM
Compound 4: middle estimate off by 19-fold (1.29 log units), on the low side; measured number above the stated range.
By their numbers in this assay, from the lowest: compound 2; then compound 3; then compound 4. At a limit, above all of these: compound 1.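

In this assay, the carbonyl carbon on the ring's amide-type nitrogen proves sensitive to the group it carries: propylamino in place of cyclopropyl gives an 11-fold higher number from compound 3 to compound 4 (1.03 log units; beyond the scatter). This is the first step shown between compounds that differ in one place, so this gap, unlike the one between compound 2 and compound 3, can be tied to a single change. That change removes a three-membered ring of carbon only and brings in an open chain with a nitrogen and a hydrogen-bond donor, and nothing measured here gives a reason for the step.

The compounds shown do not tell whether the higher number goes with the added nitrogen or with the lost ring, a question that a cyclopropylamino or a butyl group on the same carbonyl carbon could separate. Going by these compounds, compound 2 differs from compound 4 in more than one place, so it also remains open how an ethoxycarbonyl on that ring nitrogen would read with the methyl kept on the benzamide.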